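Aryl amide swap on the piperazine-bearing core

The source may hold more compounds than are shown below. What is called first, only, known or untested is meant among the compounds shown, and "the series" means these compounds.

Measured so far:
compound 1 `Cc1cc(NCCN(C)C)nc2ccc(NC(=O)c3ccc(Cl)c(Cl)c3)cc12` — 6670 nM
compound 2 `CCN(CC)CCNc1cc(C)c2cc(NC(=O)c3ccc(Cl)c(Cl)c3)ccc2n1` — 3710 nM
compound 3 `CCc1ccccc1C(=O)Nc1ccc2nc(N3CCN(CC)CC3)cc(C)c2c1` — 23900 nM

In a functional assay on SK-BR-3 cells (Homo sapiens) for antiproliferative activity, read by MTT assay, with a stated time of 72 h (on this read-out lower numbers stand for stronger inhibition and higher numbers for weaker inhibition), compound 3 gives the highest number of the three, with compound 1 its nearest neighbour and compound 2 furthest away, both gaps beyond the scatter. Compound 4 `CCN1CCN(c2cc(C)c3cc(NC(=O)c4cccc(Br)c4)ccc3n2)CC1` keeps the core of compound 3 and differs only at the amide end: 3-bromophenyl in place of 2-ethylphenyl on a carbonyl carbon. Among the measured compounds shown here, no measured pair isolates this change. For the measured compounds named here, the single step that exists, a 1.8-fold lower number from compound 1 to compound 2 (0.25 log units; within the scatter), concerns the amine side chain and lies within the scatter, so it says nothing about the aryl amide. Compounds 1 and 2 carry a dichlorinated aryl amide and sit well below compound 3, but they also differ from it in the amine part, so the lower numbers cannot be assigned to the aryl group alone. A moderate move towards the halogenated-aryl compounds is therefore expected, with wide uncertainty: the step from compound 3 to compound 4 is estimated as a 2.2-fold lower number from compound 3 to compound 4 (0.34 log units; beyond the scatter). Compound 4 is estimated at 11000 nM, within 3500 nM to 35000 nM.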

Compound 4, half-maximal inhibitory concentration: 13300 nM
Estimate against measurement, compound 4: 1.2-fold (0.08 log units) below; measured number inside the range.
By their numbers in this assay, from the lowest: compounds 2, 1, 4 and 3 (each within the scatter of the next, the first and the last beyond it).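

In this assay, among the compounds shown here, the amide end is isolated for the first time on the shared core, and the swap gives a 1.8-fold lower number from compound 3 to compound 4 (0.25 log units; within the scatter). On this core, 3-bromophenyl and 2-ethylphenyl on a carbonyl carbon therefore cannot be told apart, so this one aryl change shows no step beyond the scatter at this position. No available evidence bears on this result.

Still open, as far as these compounds go, is whether the dichlorinated aryl amide of compound 1 and compound 2 would read differently on the core of compound 3, which would separate the aryl group from the amine part. Also open, from the compounds shown here alone, is whether an aryl group carrying a carboxylic acid or an amine, or a longer chain in place of the ethyl group, would give a step beyond the scatter at the amide end.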